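Oxazolyl to hydroxymethyl-oxadiazolyl on the thiazole-piperidine ether scaffold

The source may report more compounds than this note shows. Statements on the series, on what has been measured and on what is new or still open speak of the compounds shown alone.

The measured compounds, in an assay on microsomes from liver (strain Wistar) for inhibition of acyl-CoA desaturase 1 (Rattus norvegicus), read by HPLC, with stated times of 1 h and 60 min; a lower number here means a stronger inhibitor, a higher number a weaker inhibitor:
compound 1, `NS(=O)(=O)c1cnc(N2CCC(Oc3ccccc3C(F)(F)F)CC2)s1`, gives 41 nM;
compound 2, `NC(=O)Nc1cnc(N2CCC(Oc3ccccc3C(F)(F)F)CC2)s1`, gives 150 nM;
compound 3, `FC(F)(F)c1ccccc1OC1CCN(c2ncc(-c3ncco3)s2)CC1`, gives 14 nM.

Compound 3 stands lowest of the three numbers in this assay; its nearest neighbour is compound 1, a 2.9-fold lower number from compound 1 to compound 3 (0.47 log units; beyond the scatter), and its furthest is compound 2, an 11-fold lower number from compound 2 to compound 3 (1.03 log units; beyond the scatter). The third step, a 3.7-fold higher number from compound 1 to compound 2 (0.56 log units; beyond the scatter), compares the two non-heteroaryl substituents with one another.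

Compound 4, `OCc1nc(-c2cnc(N3CCC(Oc4ccccc4C(F)(F)F)CC3)s2)no1`, has not yet been measured in this assay. It differs from compound 3 in one place: 5-(hydroxymethyl)-1,2,4-oxadiazol-3-yl in place of 1,3-oxazol-2-yl on an aromatic carbon. Going by the values given here, none of the measured steps exchanges one five-membered aromatic ring for another; the two steps that end at compound 3 only show that the five-membered aromatic ring in that place gave the lowest number among the three groups tried. The step to compound 4 keeps a five-membered aromatic ring there, so no change beyond the scatter is expected in this assay, and the estimated step is a 1.4-fold higher number from compound 3 to compound 4 (0.15 log units; within the scatter). Compound 4 is therefore expected to give about 20 nM, within a range of 6 nM to 70 nM.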

Compound 4, half-maximal inhibitory concentration: 1 nM
The estimate for compound 4 lay 20-fold (1.30 log units) above the measured number; the measured number lies below the stated range.
By their numbers in this assay, from the lowest: compound 4; then compound 3; then compound 1; then compound 2.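

In this assay, going by these compounds alone, the place next to the ring sulfur proves sensitive to which five-membered aromatic ring it carries: 5-(hydroxymethyl)-1,2,4-oxadiazol-3-yl in place of 1,3-oxazol-2-yl gives a large step (a 14-fold lower number from compound 3 to compound 4 (1.15 log units; beyond the scatter)), the first exchange of one such ring for another. The earlier compounds shown here showed only that 1,3-oxazol-2-yl gave the lowest number of the three groups, whereas the range at this place now reaches much further (a 41-fold lower number from compound 1 to compound 4 (1.61 log units; beyond the scatter); a 150-fold lower number from compound 2 to compound 4 (2.18 log units; beyond the scatter)). Compound 4 has the lowest number of the four, with every step to it beyond the scatter.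

The new group changes both the ring and the hydroxymethyl chain, so these compounds cannot separate the two, and a methyl or aminomethyl group on the same ring would be needed to test the chain. Nothing available bears on why the number fell.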